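A few compounds are considered here, and "the series" means these few. Any claim that something is new, unique, unknown or untested is made for them only; others in the source may bear on it.

Notes on the series. Compound 1 `CCCSc1nc(Cl)c2c(n1)N(CCNC(=O)OC(C)(C)C)C(C(=O)N1CCN(C)CC1)N2`, in a functional assay on TE-1 cells (Homo sapiens) for antiproliferative activity, read by MTT assay, with a stated time of 72 h (on this read-out lower numbers stand for stronger inhibition and higher numbers for weaker inhibition), gives 51800 nM. Compound 2 `CCCSc1nc(Cl)c2c(n1)N(Cc1ccccc1)C(C(=O)OCC)N2` reaches only a limit of the assay in this assay, > 64000 nM. Compound 3 `CCCSc1nc(Cl)c2c(n1)N(Cc1ccccc1)C(C(=O)NCCNC(=O)OC(C)(C)C)N2` likewise stands at a limit in this assay, > 64000 nM. The step that the two limits leave unreadable from compound 2 to compound 3 therefore cannot be read, and compound 3 sits at the limit of > 64000 nM in this assay, at which 2 of the 3 values shown sit. Compound 4 `CCCSc1nc(Cl)c2c(n1)N(Cc1ccccc1)C(C(=O)Nc1ccccc1)N2` differs from compound 3 by phenyl in place of 2-((tert-butoxycarbonyl)amino)ethyl on an amide-type nitrogen. Among the measured compounds shown here, no measured step bears on this change: the single step on record is unreadable, and compound 1 differs from compound 4 in several places at once. Compound 4 is therefore expected near the same weak level, with an expected step of an at least 1.2-fold lower number from compound 3 to compound 4 (0.10 log units; that floor lies within the scatter). The estimate for compound 4 is 50000 nM, with a range from 15000 nM to 100000 nM.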

Compound 4, half-maximal inhibitory concentration: > 64000 nM
Compound 4 gave a limit, no number; the forecaster's own chance of this, stated with the estimate: 50%; middle value at least 1.2-fold (0.10 log units) from the limit.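

Among the compounds shown here, compound 4 gives > 64000 nM in this assay and this is a limit, so no step among compound 2, compound 3 and compound 4 can be read: the limit of > 64000 nM in this assay, at which 3 of the 4 values shown sit. Going by these compounds, how far these three compounds differ in antiproliferative activity stays open.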